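The source may report more compounds than this note shows. Statements on the series, on what has been measured and on what is new or still open speak of the compounds shown alone.

Compound 1 `CCC[C@@H](OC(C)=O)C1=C(Br)[C@@](CI)(OC)OC1=O` gives 7.9 ug/mL in a functional assay on ZR-75-1 cells (Homo sapiens) for cytotoxicity; on this read-out higher numbers stand for an effect only at larger amounts of compound and lower numbers for an effect already at smaller amounts. Among the three measured compounds it holds the second highest number: compound 3 `CCCCC1=C(Br)C(=C(Br)Br)OC1=O`, which gives 8.6 ug/mL, lies close to it, while compound 2 `CCC[C@@H](O)C1=C(Br)C(=C(Br)Br)OC1=O` gives 0.3 ug/mL, a number well apart from that of compound 1. Compound 4 `CCC[C@@H](OC(C)=O)C1=C(Br)[C@](OC)(C(Br)Br)OC1=O` differs from compound 1 by dibromomethyl in place of iodomethyl on a saturated ring carbon. Among the measured compounds shown here, the only measured step, a 29-fold higher number from compound 2 to compound 3 (1.46 log units; beyond the scatter), concerns the hydroxy group on the chain, not the saturated ring carbon, and no measured step bears on an exchange of halogenated groups at that position. Lacking any comparable step, compound 4 is expected to show a 1.0-fold higher number from compound 1 to compound 4 (0.01 log units; within the scatter), that is, nothing beyond the scatter. The estimate for compound 4 is 8 ug/mL, with a range from 3 ug/mL to 20 ug/mL.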

Compound 4, concentration for half-maximal effect: 3.8 ug/mL
Estimate against measurement, compound 4: 2.1-fold (0.32 log units) above; the range from low to high includes it.
By their numbers in this assay, from the lowest: compound 2; then compound 4; then compounds 1 and 3 (each within the scatter of the next).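

Among the compounds shown here, the saturated ring carbon is not a silent place in this assay: dibromomethyl in place of iodomethyl gives a 2.1-fold lower number from compound 1 to compound 4 (0.32 log units; beyond the scatter) and so a modest step just beyond the scatter, which no earlier step could show for this position. The exchange of one halogenated group for another is thus enough to move the number with the rest of compound 1 unchanged. No measured evidence accounts for this step. Going by these compounds, whether chloromethyl or aminomethyl on this carbon would move the number further remains open. So does whether the step holds with a longer chain in place of the propyl chain.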